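The source may report more compounds than this note shows. Statements on the series, on what has been measured and on what is new or still open speak of the compounds shown alone.

In a functional assay on MGC-803 cells (Homo sapiens) for inhibition, read by MTT assay, with a stated time of 72 h (on this read-out lower numbers stand for stronger inhibition and higher numbers for weaker inhibition), compound 1 (`CCc1ccc(NC(=O)C2CCN(C/C=C/c3ccccc3)CC2)cc1`) gives 11600 nM, and compound 2 (`CC(C)c1ccc(NC(=O)C2CCN(C/C=C/c3ccccc3)CC2)cc1`) gives 5200 nM, the lower of the two numbers. Compound 3 (`COc1cccc(NC(=O)C2CCN(C/C=C/c3ccccc3)CC2)c1`) has 3-methoxyphenyl in place of 4-isopropylphenyl on an amide-type nitrogen. Going by the values given here, only one measured step bears on this change, the modest 2.2-fold lower number from compound 1 to compound 2 (0.35 log units; beyond the scatter), and it concerns a methyl on the alkyl chain. Compound 3 has no such chain, so this step is a loose guide that points towards losing that gain. The expected change is a 1.9-fold higher number from compound 2 to compound 3 (0.28 log units; within the scatter), towards a higher number. Compound 3 is estimated at 10000 nM, within a range of 3500 nM to 30000 nM.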

Compound 3, half-maximal inhibitory concentration: 37200 nM
Compound 3: the middle estimate sits 3.7-fold (0.57 log units) below what was measured, and the stated range ends below it.
By their numbers in this assay, from the lowest: compound 2; then compound 1; then compound 3.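

In this assay the group on the amide-type nitrogen proves able to shift the number further than the alkyl step did: 3-methoxyphenyl in place of 4-isopropylphenyl gives a 7.2-fold higher number from compound 2 to compound 3 (0.85 log units; beyond the scatter), and in place of 4-ethylphenyl gives a 3.2-fold higher number from compound 1 to compound 3 (0.51 log units; beyond the scatter). The change therefore does more than return to the level of compound 1, and compound 3 has the highest number of the three. Nothing at hand explains this loss.

Because group and ring position change together, the compounds leave open which of the two matters. They also leave open how a tert-butyl, ethoxy or hydroxyl group would fare here.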